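The compounds below may be only part of what the source reports. "The series", "measured", "known", "first", "only" and "open" are said of these compounds alone.

The three compounds measured so far, with their values in a functional assay on HeLa cells (Homo sapiens) for inhibition, read by MTT assay, with a stated time of 24 h; a higher number here means a weaker inhibitor, a lower number a stronger inhibitor:

Compound 1, `CCOC(=O)C1=Cc2ccccc2OC1(OCc1cc(-c2ccc(C)cc2)no1)C(F)(F)F`: > 150000 nM.
Compound 2, `CCOC(=O)C1=Cc2ccccc2OC1(OCc1cn(CC(=O)NC2CCCCC2)nn1)C(F)(F)F`: 11400 nM.
Compound 3, `CCOC(=O)C1=Cc2ccccc2OC1(OCc1cc(-c2ccc3ccccc3c2)no1)C(F)(F)F`: > 150000 nM.

The entry of compound 1 is a limit of the assay, not a number. The entry of compound 3 is likewise a limit. Among the measured compounds shown here, compound 2 therefore stands alone: it gives the only number among the three, while the other two values are limits, as summed up in the limit of > 150000 nM in this assay, at which 2 of the 3 values shown sit. For the measured compounds named here, the single step among the measured compounds, a step that the two limits leave unreadable from compound 1 to compound 3, cannot be read in size because of the limit of > 150000 nM in this assay, at which 2 of the 3 values shown sit.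

The unmeasured compound 4, `CCOC(=O)C1=Cc2ccccc2OC1(OCc1cn(-c2ccccc2)nn1)C(F)(F)F`, differs from compound 2 in one place: phenyl in place of (cyclohexylcarbamoyl)methyl on an aromatic nitrogen. Going by the values given here, no measured step touches this position; the one step that is known changes a different group and is itself unreadable. Among the compounds with values here, what remains is that the only number belongs to compound 2, and that compounds 1 and 3 sit at the limit. Compound 4 is therefore expected to come out weaker than compound 2, by an estimated step of a 3.5-fold higher number from compound 2 to compound 4 (0.55 log units; beyond the scatter). The estimate for compound 4 in this assay is 40000 nM, with a likely range from 8000 nM to 150000 nM.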

Compound 4, half-maximal inhibitory concentration: > 150000 nM
Compound 4: no number, only a limit; the forecaster's own chance of this, stated with the estimate: 35%; middle value at least 3.7-fold (0.57 log units) away from the limit.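

In this assay, among the compounds shown here, putting phenyl in place of (cyclohexylcarbamoyl)methyl on the aromatic nitrogen gives the first readable step in this set, an at least 13-fold higher number from compound 2 to compound 4 (1.11 log units; beyond the scatter). Compound 4 gives > 150000 nM, which is a limit of the assay and not a number. The earlier compounds gave no readable step at all, and this one shows that the group on this nitrogen can make a large difference to the read-out, although the true size of the step stays unknown and only its lower bound is printed, with compound 2 still the only compound that has a number: the limit of > 150000 nM in this assay, at which 3 of the 4 values shown sit.

The change removes the cyclohexyl ring, the carbonyl, the amide hydrogen and the connecting carbon in one move, and the compounds shown do not tell which of these parts matters, or whether the new phenyl itself counts against the activity. A benzyl group or a plain cyclohexyl group on the same nitrogen, or an amide chain ending in a methyl group in place of cyclohexyl, would begin to separate these parts.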